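Aryl group swap on the carbonyl: compound 2 to compound 3

The source may report more compounds than this note shows. Statements on the series, on what has been measured and on what is new or still open speak of the compounds shown alone.

Measured so far in a toxicity assay on cells (Fibroblast, Homo sapiens) for cytotoxicity (a lower number here means a stronger inhibitor, a higher number a weaker inhibitor), for this series
compound 1 `CC(/C=C/C1=CCCCC1(C)C)=C\C=C\C(C)=C\COC(=O)c1ccccc1O` gives 150000 nM
compound 2 `COc1cc(O)c(C(=O)OC/C=C(C)/C=C/C=C(C)/C=C/C2=CCCCC2(C)C)c(O)c1` gives 14000 nM

Within the data shown here, compound 2 holds the lower number of the two, and compound 1 is its only neighbour. Compound 3 (`CC(/C=C/C1=CCCCC1(C)C)=C\C=C\C(C)=C\COC(=O)c1ccc(O)cc1O`) is the next to be read in this assay and differs from compound 2 as follows: a group of 8 heavy atoms (6 carbon, 2 oxygen; one six-membered aromatic ring of carbon only) in place of a group of 10 heavy atoms (7 carbon, 3 oxygen; one six-membered aromatic ring of carbon only), on a carbonyl carbon with 2,4-dihydroxyphenyl as the entering group. Among the measured compounds shown here, the only measured step at this place is an 11-fold lower number from compound 1 to compound 2 (1.03 log units; beyond the scatter) and it is large. For the measured compounds named here, no measured step covers this exact swap. Since that step alone bears on it, a move toward a higher number is expected, smaller than that large step. The expected move is a 3.2-fold higher number from compound 2 to compound 3 (0.51 log units; beyond the scatter) on this reading. For compound 3 the expected value is 45000 nM within a range of 15000 nM to 150000 nM in this estimate.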

Compound 3, half-maximal inhibitory concentration: 120000 nM
Compound 3: the middle estimate sits 2.7-fold (0.43 log units) below what was measured, and the stated range covers the measured number.
By their numbers in this assay, from the lowest: compound 2; then compounds 3 and 1 (each within the scatter of the next).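

In this assay the aryl group on the carbonyl carbon again moves the number, with an 8.6-fold higher number from compound 2 to compound 3 (0.93 log units; beyond the scatter) as 2,4-dihydroxyphenyl enters, so the low number of compound 2 depends on the group it carries and not on any aryl group at this place. Adding one hydroxy to the ring of compound 1 does not reproduce it, giving a 1.3-fold lower number from compound 1 to compound 3 (0.10 log units; within the scatter) and leaving the group of compound 2 as the only one of the three that stands apart. No evidence at hand explains either step.

Which part of the group in compound 2 accounts for its low number stays open, since the compounds shown do not separate its features one at a time. Also open, as far as these compounds go, is how an amine or a carboxylic acid on the aromatic ring would read in this assay at this place.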